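This account rests on a few compounds, and the source may have more. Where it says the series, first, only, none or still open, it means among the compounds named here.

Of the compounds shown here, three have so far been measured in a functional assay on the whole organism with Mus musculus as the target; on this read-out lower numbers stand for an effect already at smaller amounts and higher numbers for an effect only at larger amounts of compound. Compound 1 `NC(=O)/C=C/c1cccc(C(F)(F)F)c1` gives 23.2 mg/kg in this assay. Compound 2 `O=C(/C=C/c1cccc(C(F)(F)F)c1)NC1CC1` differs from compound 1 by cyclopropyl in place of hydrogen on an amide-type nitrogen; in this assay compound 2 gives 9.6 mg/kg, and the step of a 2.4-fold lower number from compound 1 to compound 2 (0.38 log units; beyond the scatter). Compound 3 `C/C(C(N)=O)=C(\C)c1cccc(C(F)(F)F)c1` rests on a different core; how its core differs from that of compound 1 is not broken down here. In this assay compound 3 gives 32.2 mg/kg, a value within the scatter of that of compound 1. Compound 4 `C/C(C(=O)NC1CC1)=C(\C)c1cccc(C(F)(F)F)c1` is not yet measured; it differs from compound 3 by cyclopropyl in place of hydrogen on an amide-type nitrogen, the same change as that from compound 1 to compound 2. Because the step of a 2.4-fold lower number from compound 1 to compound 2 (0.38 log units; beyond the scatter) was modest, a step of about the same size is expected for compound 4, a 2.4-fold lower number from compound 3 to compound 4 (0.38 log units; beyond the scatter). Compound 4 is therefore estimated at 13.5 mg/kg, with a likely range from 7 mg/kg to 26 mg/kg.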

Compound 4, dose for half-maximal effect: 65.5 mg/kg
Estimate against measurement, compound 4: 4.9-fold (0.69 log units) below; the measured number lies above the stated range.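

Putting cyclopropyl in place of the amide hydrogen does not carry over from one core to the other: in this assay the change gives a 2.0-fold higher number from compound 3 to compound 4 (0.31 log units; beyond the scatter). Set beside the earlier step, the result differs in direction, so the effect of this change depends on the core it is made on: the same change on two cores in this assay, a 2.4-fold lower number (0.38 log units; beyond the scatter) from compound 1 to compound 2 and a 2.0-fold higher number (0.31 log units; beyond the scatter) from compound 3 to compound 4, 4.9-fold (0.69 log units) apart, beyond the scatter of two such steps. These two pairs do not show which feature of the cores is responsible, or what the same change would do on a third core.

Still open, going by these compounds, is whether a methyl group or a longer chain on the amide nitrogen would follow the same split between the cores. Also open, on these data alone, is how a carboxylic acid in place of the amide would behave on either core.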